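The source may hold more compounds than are shown below. What is called first, only, known or untested is meant among the compounds shown, and "the series" means these compounds.

Measured so far, in an assay on isolated protein for inhibition of Amine oxidase [flavin-containing] B (Homo sapiens), read by fluorescence and spectrophotometry, with a stated time of 20 min; a lower number here means a stronger inhibitor, a higher number a weaker inhibitor:

Compound 1, `O=C1/C(=C/c2ccccc2)CCc2ccc(O)cc21`: 115 nM
Compound 2, `O=C1/C(=C/c2ccc(Cl)cc2)CSc2ccccc21`: 883 nM
Compound 3, `O=C(/C=C/c1ccc(Cl)cc1)c1ccccc1`: 964 nM

Among these three, compound 1 gives the lowest number, so it is the strongest inhibitor of the set. Its distance to compound 2 and its distance to compound 3 both lie beyond the usual scatter of repeated measurements, so its lead is real and not an artefact of noise. Compound 2 and compound 3 sit close to one another, and nothing can be said about an order between them.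

The next compound to be examined is compound 4, `O=C1/C(=C/c2ccccc2)CCc2ccccc21`. It keeps the core of compound 1 and differs in one place only: hydrogen in place of hydroxy on an aromatic carbon. For the measured compounds named here, none of the measured pairs differs in just this way, so no measured step tells how this assay responds to such a change. Phenols and their unsubstituted counterparts often stay within a moderate range of one another in assays of this type, so the expectation is a small shift toward a higher number, of a size that may not exceed the scatter. The expected step is a 1.7-fold higher number from compound 1 to compound 4 (0.24 log units; within the scatter). Compound 4 is therefore estimated at 200 nM, with a likely range from 60 nM to 700 nM.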

Compound 4, half-maximal inhibitory concentration: 115 nM
Beside the measured number, compound 4's estimate is 1.7-fold (0.24 log units) above it, and the stated range covers the measured number.
By their numbers in this assay, from the lowest: compounds 1 and 4 (each within the scatter of the next); then compounds 2 and 3 (each within the scatter of the next).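

For the compounds shown here, this is the first step in the set that changes a single place, so it is the first direct reading of how this assay responds to one substitution: putting hydrogen in place of hydroxy, on the aromatic carbon that is meta to a fused ring and para to a fused ring, gives no change at the digits printed from compound 1 to compound 4 (within the scatter) on the shared core. The hydroxy group is therefore not required for the low number of compound 1, and the core of compound 1 reaches that number without it. No supporting measurement is available to explain why the number holds when this group is removed.

Going by these compounds, the result covers only the swap between hydrogen and hydroxy, so it remains open whether a methoxy group, an amine or a carboxylic acid on this same carbon would also leave the number unmoved, or would shift it in either direction. On these data alone, it is also open whether the other aromatic carbons of the core, or the unsubstituted phenyl ring, would tolerate a new group as readily as this position tolerates the loss of hydroxy.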